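Ethyl to ethoxy on the benzamide ring of compound 3

A few compounds are considered here, and "the series" means these few. Any claim that something is new, unique, unknown or untested is made for them only; others in the source may bear on it.

Measured compounds:
compound 1, `CN(C)c1ccc(C(=O)Nc2cccc(NC(=O)COc3ccc4c(c3)OCCC4=O)c2)cc1`, in an assay on isolated protein for inhibition of Rho-associated protein kinase 1 (Homo sapiens), read by scintillation counting, radiometric assay and 33P incorporation, with a stated time of 40 min, in the presence of a further agent that is not named here (a lower number here means a stronger inhibitor, a higher number a weaker inhibitor), compound 1 gives 144 nM.
compound 2, `Cc1coc2cc(OCC(=O)Nc3cccc(NC(=O)c4ccc(N(C)C)cc4)c3)ccc2c1=O`, in this assay compound 2 gives > 10000 nM; this is a limit of the assay, not a number.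
compound 3, `CCc1ccc(C(=O)Nc2cccc(NC(=O)COc3ccc4c(=O)ccoc4c3)c2)cc1`, in this assay compound 3 gives 235 nM.

Compound 3 carries the highest of the two numbers shown, but its nearest neighbour, compound 1, sits within the usual scatter of it, so no order between compound 1 and compound 3 can be read from these two values. Compound 2 is set apart only by sitting at the limit, which is the case described by the limit of > 10000 nM in this assay, at which 1 of the 3 values shown sits.

Compound 4, `CCOc1ccc(C(=O)Nc2cccc(NC(=O)COc3ccc4c(=O)ccoc4c3)c2)cc1`, is not yet measured. It differs from compound 3 in one place: ethoxy in place of ethyl on an aromatic carbon. Within the data shown here, the change sits para to a large group, and no measured pair here shows the same exchange, so its size is unknown.

Expectation: the step from compound 3 to compound 4 is estimated to be none beyond the scatter, a 1.1-fold lower number from compound 3 to compound 4 (0.03 log units; within the scatter). For compound 4 the estimated value in this assay is 220 nM, with a range from 70 nM to 700 nM.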

Compound 4, half-maximal inhibitory concentration: 17 nM
For compound 4 the middle estimate is 13-fold (1.11 log units) above the measured one, and the stated range ends above it.
By their numbers in this assay, from the lowest: compound 4; then compounds 1 and 3 (each within the scatter of the next). At a limit, above all of these: compound 2.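

Among these compounds, exchanging ethyl for ethoxy on the aromatic carbon para to a large group gives the first step that can be read in this assay (a 14-fold lower number from compound 3 to compound 4 (1.14 log units; beyond the scatter)), and it is large. Among the compounds shown here, no earlier pair differed in one place, so the compounds before this one showed nothing about this position; it now proves sensitive to the group it carries, even though the exchange keeps the same two carbons and adds only one oxygen, which counts as one hydrogen-bond acceptor. What lies behind the step cannot be told from the data here, as the only note at hand concerns the assay limit and does not bear on this result.

As far as these compounds go, with a single pair, it remains open whether the step belongs to the oxygen itself or to the whole ethoxy group, and a methoxy group, a propoxy chain or a hydroxyl group at the same position would begin to separate those readings. From the compounds shown here alone, whether ethoxy on this ring does the same on the core of compound 1 also stays open.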